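The compounds below may be only part of what the source reports. "The series", "measured", "known", "first", "only" and "open" are said of these compounds alone.

In a functional assay on HeLa cells (Homo sapiens) for antiproliferative activity, read by MTT assay, with a stated time of 72 h (a higher number here means a weaker inhibitor, a lower number a stronger inhibitor), three compounds sharing a core have been measured so far. Compound 1 `CC/C=C/C(=O)Nc1cccc(Oc2nc(Nc3ccn(C)n3)nc3c2CSCC3)c1` returned only a limit of the assay, > 50000 nM. Compound 2 `C=CC(=O)Nc1cccc(Oc2nc(Nc3cccc(OC)c3)nc3c2CSCC3)c1` gives 28900 nM, and compound 3 `C/C=C/C(=O)Nc1cccc(Oc2nc(Nc3cccc(OC)c3)nc3c2CSCC3)c1` gives 13800 nM, the lower of the two actual numbers. For the measured compounds named here, the single measured step, a 2.1-fold lower number from compound 2 to compound 3 (0.32 log units; beyond the scatter), comes with prop-1-en-1-yl in place of vinyl on a carbonyl carbon.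

Compound 4 `CC/C=C/C(=O)Nc1cccc(Oc2nc(Nc3cccc(OC)c3)nc3c2CSCC3)c1` changes the same chain again: methyl in place of hydrogen on a saturated chain carbon bound to a double-bonded chain carbon. Put another way, prop-1-en-1-yl becomes but-1-en-1-yl. Going by the values given here, only the step from vinyl bears on this change, and one pair makes no trend. Taking compound 3 and its step of a 2.1-fold lower number from compound 2 to compound 3 (0.32 log units; beyond the scatter) as the guide, a small further move toward a lower number in this assay is expected, no larger than that step and quite possibly within the scatter. The expected step is a 1.3-fold lower number from compound 3 to compound 4 (0.10 log units; within the scatter). Compound 4 is estimated at 11000 nM, with an expected range from 5000 nM to 28000 nM.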

Compound 4, half-maximal inhibitory concentration: 27200 nM
For compound 4 the middle estimate is 2.5-fold (0.39 log units) below the measured one; the measured number falls inside the stated range.
By their numbers in this assay, from the lowest: compounds 3, 4 and 2 (each within the scatter of the next, the first and the last beyond it). At a limit, above all of these: compound 1.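

In this assay, methyl in place of hydrogen on a saturated chain carbon bound to a double-bonded chain carbon does not extend the earlier step, a 2.1-fold lower number from compound 2 to compound 3 (0.32 log units; beyond the scatter), since the new change gives a 2.0-fold higher number from compound 3 to compound 4 (0.29 log units; within the scatter). Set against the vinyl compound, the but-1-en-1-yl chain gives a 1.1-fold lower number from compound 2 to compound 4 (0.03 log units; within the scatter), so compound 4 lies within the scatter of both compound 2 and compound 3, and only prop-1-en-1-yl stands clear of vinyl, with no steady trend along this chain. Compound 1 gives only a limit of the assay, > 50000 nM, and the exchange of 1-methyl-1H-pyrazol-3-yl for 3-methoxyphenyl can therefore be read only as a floor, an at least 1.8-fold lower number from compound 1 to compound 4 (0.26 log units; that floor lies within the scatter): the limit of > 50000 nM in this assay, at which 1 of the 4 values shown sits.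

As far as these compounds go, whether a longer chain such as pent-1-en-1-yl, or a dimethylamino group at the end of the chain, would move the number clear of these values remains open. From the compounds shown here alone, it also remains open how 1-methyl-1H-pyrazol-3-yl behaves with vinyl or prop-1-en-1-yl on the carbonyl carbon, so the effect of that exchange on an actual number is still unknown.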